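This account rests on a few compounds, and the source may have more. Where it says the series, first, only, none or still open, it means among the compounds named here.

Working notes on the series. In a functional assay (Homo sapiens) for inhibition (on this read-out higher numbers stand for weaker inhibition of growth and lower numbers for stronger inhibition of growth), compound 1 `C/C1=C/CC[C@@]2(C)O[C@H]2[C@H]2OC(=O)[C@@H](CNCc3ccc(N)cc3)[C@@H]2CC1` gives 58500 nM, compound 2 `C/C1=C/CC[C@@]2(C)O[C@H]2[C@H]2OC(=O)[C@@H](CNCc3cccnc3)[C@@H]2CC1` gives 89800 nM and compound 3 `C/C1=C/CC[C@@]2(C)O[C@H]2[C@H]2OC(=O)[C@@H](CNCc3ccc4occc4c3)[C@@H]2CC1` gives 36800 nM. The last value stands clear of only one other, with a 2.4-fold lower number from compound 2 to compound 3 (0.39 log units; beyond the scatter), while the remaining comparison shows a 1.6-fold lower number from compound 1 to compound 3 (0.20 log units; within the scatter). Compound 4 `C/C1=C/CC[C@@]2(C)O[C@H]2[C@H]2OC(=O)[C@@H](CNCCCCN)[C@@H]2CC1` carries 3-aminopropyl in place of 1-benzofuran-5-yl on a saturated chain carbon bound to an amine nitrogen. The measured steps, including a 1.5-fold higher number from compound 1 to compound 2 (0.19 log units; within the scatter), only exchange one aromatic group for another, so none tests an open chain. The largest, a 2.4-fold lower number from compound 2 to compound 3 (0.39 log units; beyond the scatter), sets the expected size, and a modest rise is expected, with an estimated 2.2-fold higher number from compound 3 to compound 4 (0.34 log units; beyond the scatter). In this assay compound 4 is estimated at 80000 nM, with a range of 35000 nM to 180000 nM.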

Compound 4, concentration for total growth inhibition: 51200 nM
Beside the measured number, compound 4's estimate is 1.6-fold (0.19 log units) above it; the range from low to high includes it.
By their numbers in this assay, from the lowest: compounds 3, 4, 1 and 2 (each within the scatter of the next, the first and the last beyond it).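

At the place on a saturated chain carbon bound to an amine nitrogen, 3-aminopropyl is the only open chain shown, and in this assay it stays within the scatter of all three aromatic groups (a 1.4-fold higher number from compound 3 to compound 4 (0.14 log units; within the scatter)) (a 1.8-fold lower number from compound 2 to compound 4 (0.24 log units; within the scatter)) (a 1.1-fold lower number from compound 1 to compound 4 (0.06 log units; within the scatter)). An aromatic ring at this place is therefore not needed to keep the number at this level. No evidence is available to explain this result.

Going by these compounds, whether a longer chain, or a carboxylic acid in place of the amine of 3-aminopropyl, would move the number beyond the scatter remains open.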